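Pyrazole Swap on a Shared Core, Weighed Against Two Limits

The compounds below may be only part of what the source reports. "The series", "measured", "known", "first", "only" and "open" are said of these compounds alone.

Compound 1 `Cn1ccc(-c2cccc3c2CCC3c2ncc[nH]2)n1` was examined in a functional assay on CHO cells for agonist activity at Alpha-1D adrenergic receptor (Homo sapiens), read by FLIPR and calcium flux; on this read-out lower numbers stand for an effect already at smaller amounts and higher numbers for an effect only at larger amounts of compound. In this assay compound 1 gives > 10000 nM, which is a limit of the assay and not a number. Compound 2 `CS(=O)(=O)Nc1c(Cl)ccc2c1CCCC2c1ncc[nH]1` was examined in the same way. In this assay compound 2 gives > 10000 nM, again a limit of the assay rather than a measured number. Where compound 1 stands is thus known only as a limit, and both values shown sit at the limit of > 10000 nM in this assay, at which 2 of the 2 values shown sit. Among the measured compounds shown here, no two measured compounds differ in a single place, so no measured step is available from which the weight of a single change could be read.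

Compound 3 `c1cc(-c2cn[nH]c2)c2c(c1)C(c1ncc[nH]1)CC2` has not yet been measured. It differs from compound 1 by 1H-pyrazol-4-yl in place of 1-methyl-1H-pyrazol-3-yl on an aromatic carbon. With both known values resting at the limit, nothing in the data points to a direction for this change. The author expects no step beyond the usual scatter, and the estimated step is a step that the limit leaves unreadable from compound 1 to compound 3. Compound 3 is expected to give 15000 nM, with a range from 3000 nM to 100000 nM, and most likely the assay will once more report only a limit.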

Compound 3, half-maximal effective concentration: 319 nM
Compound 3: middle estimate off by 47-fold (1.67 log units), on the high side, and the stated range ends above it.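

In this assay, the exchange of 1-methyl-1H-pyrazol-3-yl for 1H-pyrazol-4-yl on this aromatic carbon gives the only readable step among the compounds shown (an at least 31-fold lower number from compound 1 to compound 3 (1.49 log units; beyond the scatter)), so what sits at this place on the shared core clearly matters, even though a five-membered aromatic ring with 2 hetero atoms stands there on both sides. The change nevertheless has several parts: the entering group has 1 hydrogen-bond donor where the leaving group has 0, it lacks the methyl, and its ring is joined through a different ring carbon. The step can be given only as a bound because compound 1 rests at a limit of the assay and not at a number: the limit of > 10000 nM in this assay, at which 2 of the 3 values shown sit.

The compounds shown leave open which part of this change carries the step, and 1-methyl-1H-pyrazol-4-yl at the same carbon would separate the methyl from the point of attachment. They also leave open whether a non-ring group at this carbon, such as an amine or a carboxylic acid, would keep a measurable value in this assay.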